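Morpholine amide on the acrylamide series: compound 4

This account rests on a few compounds, and the source may have more. Where it says the series, first, only, none or still open, it means among the compounds named here.

Measured so far in an assay on a protein complex for inhibition of CDK8/Cyclin C (Homo sapiens), with a stated time of 1 h, tested at 10 uM; on this read-out higher numbers stand for more inhibition at the one concentration tested (going by the name of the read-out) and lower numbers for less inhibition:
compound 1 `O=C(O)[C@@H]1CCCN1C(=O)/C=C/c1ccncc1-c1ccc2ccccc2c1` gives 67%
compound 2 `NNC(=O)CCc1ccncc1-c1ccc2ccccc2c1` gives 102%
compound 3 `CNC(=O)/C=C/c1ccncc1-c1ccc2cc[nH]c2c1` gives 103%

Compound 3 stands highest of the three numbers in this assay. Compound 2 lies within the scatter of compound 3, so the two cannot be ordered. Compound 1 lies beyond the scatter below compound 3, the one clear separation in the set. Going by the values given here, no two measured compounds differ in only one place, so no measured step is available, and nothing measured tracks a change at the terminal amide alone: compound 1 and compound 3 differ in more than one place.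

Compound 4 `O=C(/C=C/c1ccncc1-c1ccc2cc[nH]c2c1)N1CCOCC1` is the next candidate for this assay. It differs from compound 3 in one place, (morpholin-4-yl in place of methylamino on a carbonyl carbon).

Since compound 3 already gives a high number at the single concentration, the step in this assay from compound 3 to compound 4 is expected to stay within the scatter or to fall slightly, an expected a number 8 percentage points lower from compound 3 to compound 4 (within the scatter). Compound 4 is therefore estimated at 95% in this assay, expected to lie between 75% and 105%.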

Compound 4, a percentage reported as inhibition, at one concentration (the size of the read-out at that concentration, not a potency): 102%
The estimate for compound 4 lay 7 percentage points below the measured number; the range from low to high includes it.
By their numbers in this assay, from the lowest: compound 1; then compounds 2, 4 and 3 (each within the scatter of the next).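

In this assay, going by these compounds alone, morpholin-4-yl in place of methylamino on the carbonyl carbon gives a number 1 percentage points lower from compound 3 to compound 4 (within the scatter), the first measured step that isolates a change at this place. The exchange removes the one hydrogen-bond donor of methylamino and brings in a six-membered non-aromatic ring with 6 heavy atoms in place of 2, yet the read-out at the one concentration does not separate the two compounds. No measurement at hand bears on why the two numbers lie so close.

Still open, as far as these compounds go, is whether other groups on the same carbonyl carbon, such as dimethylamino with no amide hydrogen and no ring, or 4-methylpiperazin-1-yl with a second ring nitrogen carrying a methyl group, would also stay within the scatter of compound 3. Also open, from the compounds shown here alone, is whether compound 3 and compound 4 would remain inseparable in a full concentration series, since a percentage at a single concentration is not a potency.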